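The compounds below may be only part of what the source reports. "The series", "measured", "known", "first", "only" and "open" are said of these compounds alone.

Working notes on the series. For the measured compounds named here, in a functional assay on NCI-H460 cells (Homo sapiens) for inhibition, read by sulforhodamine B assay, with a stated time of 48 h (on this read-out higher numbers stand for weaker inhibition of growth and lower numbers for stronger inhibition of growth), compound 2 (`NC(=O)c1cc(Br)ccc1NC(=O)/C=C/c1ccccc1`) gives 662 nM and holds the lower of the two numbers so far, while compound 1 (`Cc1ccc(NC(=O)/C=C/c2ccccc2)c(C(N)=O)c1`) gives 3590 nM as its only neighbour. Next comes compound 3 (`NC(=O)c1cc(I)ccc1NC(=O)/C=C/c1ccccc1`), which differs from compound 2 in one place: iodo in place of bromo on an aromatic carbon (iodo in place of bromo on an aromatic carbon, meta to a carbamoyl group and para to a large group).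

Going by the values given here, one measured step bears on this change: a 5.4-fold lower number from compound 1 to compound 2 (0.73 log units; beyond the scatter) for bromo in place of methyl on an aromatic carbon, modest and beyond the scatter. Among the compounds with values here, no measured step links bromo to iodo, so this single step is only a loose guide. In this assay a change within the scatter is therefore expected, leaning if anything towards a lower number, the direction of that one step. The expected step is a 1.2-fold lower number from compound 2 to compound 3 (0.08 log units; within the scatter) on this estimate. For compound 3 the estimated value is 550 nM (expected range 220 nM to 1400 nM).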

Compound 3, concentration for 50% growth inhibition: 453 nM
For compound 3 the middle estimate is 1.2-fold (0.08 log units) above the measured one; measured number inside the range.
By their numbers in this assay, from the lowest: compounds 3 and 2 (each within the scatter of the next); then compound 1.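

The exchange of bromo for iodo on this aromatic carbon, meta to a carbamoyl group and para to a large group, stays within the scatter in this assay (a 1.5-fold lower number from compound 2 to compound 3 (0.16 log units; within the scatter)), so compound 2 and compound 3 cannot be separated on this read-out. Iodo in place of methyl gives a 7.9-fold lower number from compound 1 to compound 3 (0.90 log units; beyond the scatter) and lies beyond the scatter, so a second group now joins bromo (a 5.4-fold lower number from compound 1 to compound 2 (0.73 log units; beyond the scatter)) in giving a clearly lower number than methyl at this position, and compound 1 stands apart from the other two. No measurement at hand accounts for these differences or for the closeness of compound 2 and compound 3.

The compounds shown leave open whether chloro, fluoro, methoxy or an amine on the same carbon would stay level with bromo and iodo or return towards methyl in this assay. They also leave open whether the lower numbers seen with bromo and iodo persist when the carbamoyl group gives way to a carboxylic acid, as all three compounds carry the carbamoyl group.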